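Swapping one amine for a smaller bicyclic one

This account rests on a few compounds, and the source may have more. Where it says the series, first, only, none or still open, it means among the compounds named here.

Measured so far:
compound 1 `COc1ccc2[nH]c(C(=O)N3CC(=O)N(Cc4ccccc4)[C@@H](CN4CCC(C)CC4)C3)cc2c1`: > 30000 nM
compound 2 `COc1ccc2[nH]c(C(=O)N3CC(=O)N(Cc4ccccc4)[C@@H](CN4CCN(c5ccccn5)CC4)C3)cc2c1`: > 30000 nM

In an ADME assay on Vero cells (Chlorocebus sabaeus) for cytotoxicity, with a stated time of 7 days (on this read-out lower numbers stand for higher toxicity in this test and higher numbers for lower toxicity in this test), compound 1 gives > 30000 nM, which is a limit of the test rather than a number. In this assay compound 2 gives > 30000 nM, again a limit. Compound 2 therefore stands at the limit of > 30000 nM in this assay, at which 2 of the 2 values shown sit, and the step that the two limits leave unreadable from compound 1 to compound 2 cannot be read, since both ends rest on that limit. Compound 3 `COc1ccc2[nH]c(C(=O)N3CC(=O)N(Cc4ccccc4)[C@@H](CN4CCn5cccc5C4)C3)cc2c1` differs from compound 2 by a group of 9 heavy atoms (7 carbon, 2 nitrogen; one five-membered aromatic ring with 1 hetero atom, one six-membered non-aromatic ring with 2 hetero atoms) in place of a group of 12 heavy atoms (9 carbon, 3 nitrogen; one six-membered non-aromatic ring with 2 hetero atoms, one six-membered aromatic ring with 1 hetero atom), on a saturated chain carbon bound to a saturated ring carbon. Among the compounds with values here, no measured step reports a readable size, so the expectation rests only on where compound 2 sits. Compound 3 is expected to show no change beyond the scatter, with a number no higher from compound 2 to compound 3 (the limit leaves the size open) as the estimated step, and most likely to rest at the same limit. The estimate for compound 3 in this assay is 30000 nM, between 12000 nM and 80000 nM.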

Compound 3, half-maximal cytotoxic concentration: > 100000 nM
Compound 3 ended at the assay's limit (the forecaster's own chance of this, stated with the estimate: 75%); at least 3.3-fold (0.52 log units) between middle value and limit.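

Within the data shown here, compound 1, compound 2 and compound 3 all rest on limits of the test rather than on numbers, so no step among them can be read. The compounds shown leave open how the three groups rank in toxicity, and at what concentration, if any, each compound becomes toxic.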